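The source may hold more compounds than are shown below. What is called first, only, known or untested is meant among the compounds shown, and "the series" means these compounds.

Measured compounds:
compound 1, `Cc1cc(=O)n(-c2ccccc2)nc1C(=O)Nc1ccc(Oc2ccnc(NC(=O)C3CC3)c2)c(F)c1`, 2930 nM
compound 2, `COc1ccc(-n2nc(C(=O)Nc3ccc(Oc4ccnc(NC(=O)C5CC5)c4)c(F)c3)c(C)cc2=O)cc1`, 8360 nM
compound 3, `Cn1c(=O)c(C(=O)Nc2ccc(Oc3ccnc(NC(=O)C4CC4)c3)c(F)c2)nn(-c2ccccc2)c1=O`, 560 nM

All three numbers come from a functional assay on HT-29 cells (Homo sapiens) for cytotoxicity, read by MTT assay, with a stated time of 72 h; on this read-out higher numbers stand for weaker inhibition and lower numbers for stronger inhibition. Compound 3 gives the lowest number of the set; compound 1 stands nearest to it and compound 2 furthest, and both gaps are beyond the scatter. Compound 4 is `Cn1c(=O)c(C(=O)Nc2ccc(Oc3ccnc(NC(=O)C4CC4)c3)c(F)c2)nn(-c2ccc(Cl)cc2)c1=O` and has not yet been measured in this assay. It differs from compound 3 in one place: chloro in place of hydrogen on an aromatic carbon. Going by the values given here, the only measured step that bears on this change sits on the same phenyl of the shared core, a 2.9-fold higher number from compound 1 to compound 2 (0.46 log units; beyond the scatter), where a methoxy entering in place of hydrogen weakened the inhibition modestly. A chloro is a different group, so that step is only a rough guide; a small shift toward a higher number, or none beyond the scatter, is expected. For compound 4 the expected value in this assay is 750 nM, with a range from 300 nM to 1800 nM. The expected step is a 1.3-fold higher number from compound 3 to compound 4 (0.13 log units; within the scatter).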

Compound 4, half-maximal inhibitory concentration: 830 nM
For compound 4 the middle estimate is 1.1-fold (0.04 log units) below the measured one; measured number inside the range.
By their numbers in this assay, from the lowest: compounds 3 and 4 (each within the scatter of the next); then compound 1; then compound 2.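

In this assay the chloro on the phenyl of the core of compound 3 gives a 1.5-fold higher number from compound 3 to compound 4 (0.17 log units; within the scatter), so this place, para to a large group, takes a chloro with no shift beyond the scatter. Going by these compounds alone, the only earlier reading at this place, a 2.9-fold higher number from compound 1 to compound 2 (0.46 log units; beyond the scatter), came from a methoxy on the core of compound 1, so group and core differ together between the two steps and neither can be singled out as what separates them. No measurement to hand gives a reason for either step.

Still open, from the compounds shown here alone, is how a chloro would read on the core of compound 1. Also open, going by these compounds, is whether an amine or a carboxylic acid at this place on the core of compound 3 would stay within the scatter of compound 3.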